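The source may hold more compounds than are shown below. What is called first, only, known or untested is meant among the compounds shown, and "the series" means these compounds.

Measured so far in a functional assay on the whole organism (strain albino) for inhibition, with Rattus norvegicus as the target, read by paw edema, with stated times of 30 min and 3 h, at a dose of 100 mg/kg by the oral route; a higher number here means more inhibition at the dose given (going by the name of the read-out), a lower number less inhibition: compound 1 `COc1ccc(/C=C/C(=O)c2ccc(NC(=O)COc3ccc(C(C)=O)cc3)cc2)cc1` gives 42%; compound 2 `CC(=O)c1ccc(OCC(=O)Nc2ccc(C(=O)/C=C/c3ccco3)cc2)cc1` gives 45%.

Among the measured compounds shown here, the only step between them, a number 3 percentage points higher from compound 1 to compound 2 (within the scatter), keeps the two within the scatter of each other, so compound 2 stands apart from nothing. Compound 3 `C/C(=N/O)c1ccc(OCC(=O)Nc2ccc(C(=O)/C=C/c3ccco3)cc2)cc1` carries a group of 4 heavy atoms (2 carbon, 1 nitrogen, 1 oxygen; no ring) in place of a group of 3 heavy atoms (2 carbon, 1 oxygen; no ring), on an aromatic carbon. For the measured compounds named here, the single measured step concerns the group on the double-bonded chain carbon, not the acetyl, so no measured step bears on this change and nothing points in either direction. The expected step is therefore no change at the digits printed from compound 2 to compound 3 (within the scatter), nothing beyond the scatter. Compound 3 is estimated at 45%, range 30% to 60%.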

Compound 3, a percentage reported as inhibition, in the whole organism at one dose (the size of the read-out at that dose, not a potency): 49%
Compound 3: middle estimate off by 4 percentage points, on the low side; measured number inside the range.
By their numbers in this assay, from the lowest: compounds 1, 2 and 3 (each within the scatter of the next).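

Swapping acetyl for the group of 4 heavy atoms, on an aromatic carbon para to a large group, gives in this assay a number 4 percentage points higher from compound 2 to compound 3 (within the scatter). Among the compounds shown here, this is the first reading at this position, and it shows that a group carrying a hydrogen-bond donor can stand there without a shift beyond the scatter. No available evidence bears on the reason for this result.

As far as these compounds go, whether an amine, a carboxylic acid or a longer chain at this position would move the read-out beyond the scatter remains open. Also open, from the compounds shown here alone, is whether the same exchange gives a similar result with 4-methoxyphenyl in place of furan-2-yl.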